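The compounds below may be only part of what the source reports. "The series", "measured", "known", "first", "only" and "open" are said of these compounds alone.

Compound 2 `Cn1ncc(Cl)c1-c1cc(C(=O)N[C@@H]2CN[C@H](CC(=O)O)C[C@H]2c2ccc(Cl)c(Cl)c2)oc1Cl` gives 1.94 nM in an assay for inhibition of RAC-alpha serine/threonine-protein kinase (Homo sapiens), read by HTRF, with a stated time of 1 h; a lower number here means a stronger inhibitor, a higher number a weaker inhibitor. Compound 1 `Cn1ncc(Cl)c1-c1cc(C(=O)N[C@@H]2CN[C@H](CCO)C[C@H]2c2ccc(F)c(F)c2)oc1Cl` gives 0.98 nM and compound 3 `CC(=O)OCC[C@@H]1C[C@@H](c2ccc(F)c(F)c2)[C@H](NC(=O)c2cc(-c3c(Cl)cnn3C)c(Cl)o2)CN1` gives 3.4 nM; compound 2 lies within the scatter of both, so its number sets no order among the three. Compound 4 `COCC[C@@H]1C[C@@H](c2ccc(Cl)c(Cl)c2)[C@H](NC(=O)c2cc(-c3c(Cl)cnn3C)c(Cl)o2)CN1` is not yet measured and differs from compound 2 by methoxymethyl in place of carboxy on a saturated chain carbon bound to a saturated ring carbon. Within the data shown here, no measured pair makes exactly this change. Among the measured compounds shown here, the one measured step, a 3.5-fold higher number from compound 1 to compound 3 (0.54 log units; beyond the scatter), put acetyl in place of hydrogen on an oxygen on a saturated carbon and was modest; the change to compound 4 also removes the hydrogen-bond donor from the chain. A similar modest weakening is expected, and the expected step is a 1.8-fold higher number from compound 2 to compound 4 (0.26 log units; within the scatter). The estimate for compound 4 is 3.5 nM, with a range from 1.2 nM to 10 nM.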

Compound 4, half-maximal inhibitory concentration: 7.01 nM
Beside the measured number, compound 4's estimate is 2.0-fold (0.30 log units) below it; low and high end bracket the measured number.
By their numbers in this assay, from the lowest: compounds 1, 2 and 3 (each within the scatter of the next, the first and the last beyond it); then compound 4.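

In this assay, the chain on this saturated ring carbon now shows a second modest step beyond the scatter, a 3.6-fold higher number from compound 2 to compound 4 (0.56 log units; beyond the scatter), and the entering methoxymethyl carries no hydrogen-bond donors. The earlier step, a 3.5-fold higher number from compound 1 to compound 3 (0.54 log units; beyond the scatter), changed only the end of a hydroxyl-bearing chain, whereas this one replaces carboxy outright. Nothing measured here explains the size of the new step. The compounds shown leave open how an amine or a longer chain would read at this place, and whether a simple methyl would do the same.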